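From Fluoro to Methoxy on the Aromatic Carbon

The compounds below may be only part of what the source reports. "The series", "measured", "known", "first", "only" and "open" are said of these compounds alone.

compound 1: `CCc1nnc2sc(-c3c[nH]nc3-c3ccccc3)nn12` — 29.4%
compound 2: `CCc1nnc2sc(-c3c[nH]nc3-c3ccc(F)cc3)nn12` — 23.5%

In a functional assay on the whole organism (strain Wistar) for inhibition, with Rattus norvegicus as the target, read by paw edema, with stated times of 30 min and 2.5 h, at a dose of 20 mg/kg by the intraperitoneal route (a higher number here means more inhibition at the dose given (going by the name of the read-out), a lower number less inhibition), compound 1 gives 29.4% and compound 2 gives 23.5%. For the measured compounds named here, compound 2 sits within the scatter of compound 1, the only other compound measured, the step of a number 5.9 percentage points lower from compound 1 to compound 2 (within the scatter) being too small to speak of a change. Compound 3, `CCc1nnc2sc(-c3c[nH]nc3-c3ccc(OC)cc3)nn12`, differs from compound 2 by methoxy in place of fluoro on an aromatic carbon. Going by the values given here, the only measured step, a number 5.9 percentage points lower from compound 1 to compound 2 (within the scatter), lies within the scatter and does not involve methoxy; no measured step shows what methoxy does at this position. As far as these compounds go, on that basis the expected step, a number 2.5 percentage points higher from compound 2 to compound 3 (within the scatter), is none beyond the scatter, with the range widened because the methoxy change is untested. Compound 3 is therefore estimated at 26%, expected to fall between 10% and 42%.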

Compound 3, a percentage reported as inhibition, in the whole organism at one dose (the size of the read-out at that dose, not a potency): 17.6%
Compound 3: middle estimate off by 8.4 percentage points, on the high side; the measured number falls inside the stated range.
By their numbers in this assay, from the lowest: compounds 3, 2 and 1 (each within the scatter of the next, the first and the last beyond it).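

In this assay, for the compounds shown here, methoxy in place of hydrogen on the aromatic carbon gives the first step at this position that lies beyond the scatter, a number 11.8 percentage points lower from compound 1 to compound 3 (beyond the scatter). Set against fluoro, the same group gives a step within the scatter, a number 5.9 percentage points lower from compound 2 to compound 3 (within the scatter), so the compounds separate methoxy from hydrogen but not methoxy from fluoro, and compound 2 stays within the scatter of both compound 1 and compound 3. No evidence is at hand that bears on why methoxy differs from hydrogen here.

As far as these compounds go, what remains open is how the read-out responds to other groups at this carbon, such as an amine, a carboxylic acid or the longer ethoxy chain. Also open, from the compounds shown here alone, is whether the step from hydrogen to methoxy would hold if the ethyl group on the shared core were replaced by a longer chain.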